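This account rests on a few compounds, and the source may have more. Where it says the series, first, only, none or still open, it means among the compounds named here.

Measured so far: compound 1 `CC1(C)[C@H]2CC[C@]1(C)N(Cc1cn(-c3cccc(F)c3)nn1)C(=O)C2` with 180 nM in a functional assay on A549 cells (Homo sapiens) for inhibition, read by MTT assay, with a stated time of 24 h; a lower number here means a stronger inhibitor, a higher number a weaker inhibitor; compound 2 `CC1(C)[C@H]2CC[C@]1(C)N(Cc1cn(-c3ccccc3C#N)nn1)C(=O)C2` with 100 nM; compound 3 `COc1ccccc1-n1cc(CN2C(=O)C[C@@H]3CC[C@@]2(C)C3(C)C)nn1` with 350 nM.

Among these three numbers compound 1 stands second highest. Its nearest neighbour is compound 2, reached by a 1.8-fold lower number from compound 1 to compound 2 (0.26 log units; within the scatter), and its furthest is compound 3, reached by a 1.9-fold higher number from compound 1 to compound 3 (0.29 log units; within the scatter); both of these steps stay within the scatter, so the three compounds cannot be ranked against each other on these data alone. Among the compounds with values here, only the step of a 3.5-fold higher number from compound 2 to compound 3 (0.54 log units; beyond the scatter) is modest and beyond the scatter.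

Compound 4 `CC1(C)[C@H]2CC[C@]1(C)N(Cc1cn(-c3ccc(O)cc3)nn1)C(=O)C2` has not yet been measured. It differs from compound 1 in one place: 4-hydroxyphenyl in place of 3-fluorophenyl on an aromatic nitrogen. The two measured steps that bear on this change, a 1.8-fold lower number from compound 1 to compound 2 (0.26 log units; within the scatter) and a 1.9-fold higher number from compound 1 to compound 3 (0.29 log units; within the scatter), each exchange the 3-fluorophenyl for another phenyl group on the same aromatic nitrogen, and neither moves the number beyond the scatter. No measured step involves a hydroxyl group or a 4-hydroxyphenyl, so the direction of any effect is not shown. The expectation for compound 4 is therefore no change beyond the scatter, with a wider range to allow for the new hydrogen-bond donor and acceptor: the estimated step is a 1.4-fold higher number from compound 1 to compound 4 (0.14 log units; within the scatter). Compound 4 is estimated at 250 nM, with a range from 80 nM to 800 nM.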

Compound 4, half-maximal inhibitory concentration: 140 nM
Beside the measured number, compound 4's estimate is 1.8-fold (0.25 log units) above it; the measured number falls inside the stated range.
By their numbers in this assay, from the lowest: compounds 2, 4, 1 and 3 (each within the scatter of the next, the first and the last beyond it).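

In this assay, the exchange of 3-fluorophenyl for 4-hydroxyphenyl on the aromatic nitrogen brings in a hydrogen-bond donor and acceptor, yet the step stays within the scatter: a 1.3-fold lower number from compound 1 to compound 4 (0.11 log units; within the scatter). Compound 4 also stays within the scatter of the 2-cyanophenyl compound, a 1.4-fold higher number from compound 2 to compound 4 (0.15 log units; within the scatter), but lies beyond it from the 2-methoxyphenyl compound, a 2.5-fold lower number from compound 3 to compound 4 (0.40 log units; beyond the scatter), a modest step, so the four phenyl groups shown at this position differ only modestly, and compound 1 lies within the scatter of all three others. No measurement at hand explains these numbers or links them to any property of the groups.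

The compounds shown leave open whether the hydroxyl contributes anything here, as the plain unsubstituted phenyl is not among them, and a hydroxyl on this phenyl is seen at only one place. They also leave open whether an amine or a carboxylic acid in place of that hydroxyl, or a saturated alkyl chain in place of the whole phenyl, would stay within the same narrow span.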